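Thiourea and urea esters: a para-substituent swap on growth inhibition

This account rests on a few compounds, and the source may have more. Where it says the series, first, only, none or still open, it means among the compounds named here.

Measured compounds and values:
compound 1, `CCOC(=O)C1=C(C)NC(=S)NC1c1ccc(O)cc1`, 47.6 ug/mL;
compound 2, `CCCc1ccc(C2NC(=S)NC(C)=C2C(=O)OCC)cc1`, 42.4 ug/mL;
compound 3, `CCCc1ccc(C2NC(=O)NC(C)=C2C(=O)OCC)cc1`, 25 ug/mL.

The three measured compounds were tested in a functional assay on PC-3 cells (Homo sapiens) for inhibition, read by sulforhodamine B assay, with a stated time of 48 h; a lower number here means a stronger inhibitor of growth, a higher number a weaker inhibitor of growth. Compound 1 has structure `CCOC(=O)C1=C(C)NC(=S)NC1c1ccc(O)cc1` and in this assay compound 1 gives 47.6 ug/mL. Compound 2, `CCCc1ccc(C2NC(=S)NC(C)=C2C(=O)OCC)cc1`, gives 42.4 ug/mL in this assay. Compound 3, `CCCc1ccc(C2NC(=O)NC(C)=C2C(=O)OCC)cc1`, gives 25 ug/mL, which sits within the scatter of both other values; no ordering among the three can be claimed. The difference between the cores of compound 3 and compound 2 is not broken down here.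

One change is seen twice. From compound 2 to compound 1 the change is hydroxy in place of propyl on an aromatic carbon, and its step was a 1.1-fold higher number from compound 2 to compound 1 (0.05 log units; within the scatter). From compound 3 to the unmeasured compound 4, `CCOC(=O)C1=C(C)NC(=O)NC1c1ccc(O)cc1`, the same change is made: hydroxy in place of propyl on an aromatic carbon.

Because the step of a 1.1-fold higher number from compound 2 to compound 1 (0.05 log units; within the scatter) was within the scatter, a comparably small step is expected from compound 3 to compound 4, namely a 1.1-fold higher number from compound 3 to compound 4 (0.05 log units; within the scatter). Compound 4 is therefore estimated at 28 ug/mL in this assay, with a likely range from 15 ug/mL to 52 ug/mL.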

Compound 4, concentration for 50% growth inhibition: 136 ug/mL
Compound 4: the middle estimate sits 4.9-fold (0.69 log units) below what was measured; the measured number lies above the stated range.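

In this assay, hydroxy in place of propyl on an aromatic carbon gave a 5.4-fold higher number from compound 3 to compound 4 (0.74 log units; beyond the scatter), so a step read on the core of compound 2 did not predict the size of the step on the core of compound 3. In this pair of cores, the effect of the swap therefore depends on the core that carries it: the same change on two cores in this assay, a 1.1-fold higher number (0.05 log units; within the scatter) from compound 2 to compound 1 and a 5.4-fold higher number (0.74 log units; beyond the scatter) from compound 3 to compound 4, 4.8-fold (0.69 log units) apart, beyond the scatter of two such steps

Among the compounds shown here, this rests on only two pairs of compounds, and it shows neither why the two steps part nor how the same change would behave on any further core.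

The compounds shown carry only propyl and hydroxy at this place, so it remains open whether a methoxy group, a chlorine atom, an amine or a longer chain would follow the small step or the large one on these two cores. On these data alone, it is also open whether the gap between the two steps seen in this assay would appear in any other cell line.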